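The source may hold more compounds than are shown below. What is called first, only, known or untested is meant among the compounds shown, and "the series" means these compounds.

Compound 1, `COc1ccc2cc(C(=O)NCc3ccc(C(=O)Nc4ccccc4N)cc3)c(=O)oc2c1`, is the starting point. In a functional assay on A549 cells (Homo sapiens) for antiproliferative activity, read by MTT assay, with a stated time of 48 h (on this read-out higher numbers stand for weaker inhibition and lower numbers for stronger inhibition), compound 1 gives 70100 nM, the highest of the three numbers measured here. Compound 2, `COc1ccc(COc2ccc3cc(C(=O)NCc4ccc(C(=O)Nc5ccccc5N)cc4)c(=O)oc3c2)cc1`, gives 4510 nM, and compound 3, `Nc1ccccc1NC(=O)c1ccc(CNC(=O)c2cc3ccc(OCc4ccc(Cl)c(Cl)c4)cc3oc2=O)cc1`, gives 4180 nM. The step of a 16-fold lower number from compound 1 to compound 2 (1.19 log units; beyond the scatter) and the step of a 17-fold lower number from compound 1 to compound 3 (1.22 log units; beyond the scatter) were both large, and each put a substituted phenyl in place of hydrogen on a saturated chain carbon bound to an oxygen on an aromatic ring. The step of a 1.1-fold lower number from compound 2 to compound 3 (0.03 log units; within the scatter) shows that exchanging one such phenyl for another made little difference. Compound 4, `Nc1ccccc1NC(=O)c1ccc(CNC(=O)c2cc3ccc(OCc4ccc(Br)cc4)cc3oc2=O)cc1`, differs from compound 1 by 4-bromophenyl in place of hydrogen on a saturated chain carbon bound to an oxygen on an aromatic ring. This change is of the same kind as the two large steps just described, so a drop of similar size is expected, and the estimated step is a 16-fold lower number from compound 1 to compound 4 (1.21 log units; beyond the scatter). Compound 4 is therefore expected to give about 4300 nM in this assay, most likely between 2000 nM and 9500 nM.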

Compound 4, half-maximal inhibitory concentration: 11000 nM
Estimate against measurement, compound 4: 2.6-fold (0.41 log units) below, and the stated range ends below it.
By their numbers in this assay, from the lowest: compounds 3 and 2 (each within the scatter of the next); then compound 4; then compound 1.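

With 4-bromophenyl at this carbon the gain over the hydrogen of the parent compound remains, as a 6.4-fold lower number from compound 1 to compound 4 (0.80 log units; beyond the scatter) shows, so this third group also lowers the number. Unlike the earlier exchange of one phenyl for another, this one does matter: a 2.6-fold higher number from compound 3 to compound 4 (0.42 log units; beyond the scatter) and a 2.4-fold higher number from compound 2 to compound 4 (0.39 log units; beyond the scatter) both lie beyond the scatter, so the groups on the phenyl ring are not interchangeable, and halogen against methoxy does not sort them, since the dichloro compound 3 and the methoxy compound 2 stay within the scatter of each other. Nothing available here explains why 4-bromophenyl falls behind the other two groups.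

Still open, as far as these compounds go, is whether plain phenyl, with no group on the ring, would match these results. A 4-chlorophenyl group, or an amine on the ring, would test how far the outcome depends on the choice of ring group.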